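Three aryl groups on a shared core, and an iodophenyl follows

The source may hold more compounds than are shown below. What is called first, only, known or untested is meant among the compounds shown, and "the series" means these compounds.

Of the compounds shown here, three on a shared core have been measured in a physicochemical assay for lipophilicity; on this read-out higher numbers stand for higher lipophilicity and lower numbers for lower lipophilicity. Compound 1 `CCOC(=O)C1=C(C)N=C(C)/C(=C(/O)OCC)C1c1ccccc1OC` gives 3.19 in this assay, the lowest of the three numbers. Compound 3 `CCO/C(O)=C1\C(C)=NC(C)=C(C(=O)OC)C1c1ccc([N+](=O)[O-])cc1` gives 3.6, the nearest to it and beyond the scatter. Compound 2 `CCO/C(O)=C1\C(C)=NC(C)=C(C(=O)OC)C1c1cccc(C(F)(F)F)c1` gives 3.9, the furthest from compound 1 and also beyond the scatter.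

Compound 4 `CCOC(=O)C1=C(C)N=C(C)/C(=C(/O)OCC)C1c1cccc(I)c1` has not yet been measured. It differs from compound 1 in one place: 3-iodophenyl in place of 2-methoxyphenyl on a saturated ring carbon. Going by the values given here, no measured pair shows this change directly, so its size can only be expected from the spread seen among compounds 1, 2 and 3 in this assay.

The step from compound 1 to compound 4 is expected to be upward and clearly beyond the scatter, with a number 1.01 log units higher from compound 1 to compound 4 (beyond the scatter) as the estimated size. In this assay compound 4 is expected to give 4.2, in a range from 3.8 to 4.6. The measurement will show whether the number lands there.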

Compound 4, partition coefficient: 4.48
Compound 4: middle estimate off by 0.28 log units, on the low side; the range from low to high includes it.
By their numbers in this assay, from the lowest: compound 1; then compounds 3 and 2 (each within the scatter of the next); then compound 4.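

In this assay, putting 3-iodophenyl in place of 2-methoxyphenyl on the saturated ring carbon gives a number 1.29 log units higher from compound 1 to compound 4 (beyond the scatter), a large step and the first one in this series that can be read between two compounds differing in one place. It shows that this position, on a saturated ring carbon next to the ring atom that bears an ethoxycarbonyl group, can carry a large change in this read-out when only the aryl group is exchanged. The change swaps an oxygen-bearing group with one hydrogen-bond acceptor for an iodine-bearing group with none, but nothing available explains the size of the step.

As far as these compounds go, what remains open is how much of the step belongs to the iodine and how much to where each group sits on the phenyl ring. A 3-methoxyphenyl or a 2-iodophenyl group on the same carbon would separate the two, and a 3-bromophenyl group would show how far the step depends on iodine itself.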